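A Nitro-to-Cyano Change Carried to a Second Core

A few compounds are considered here, and "the series" means these few. Any claim that something is new, unique, unknown or untested is made for them only; others in the source may bear on it.

Of the compounds shown here, three have been measured in a functional assay on MC-38 cells (Mus musculus) for antiproliferative activity, read by colorimetric assay and MTT assay; on this read-out lower numbers stand for stronger inhibition and higher numbers for weaker inhibition. Compound 1 `O=[N+]([O-])c1ccc(S(=O)(=O)Nc2cccc3c(Cl)c[nH]c23)cc1` gives 0.34 ug/mL, and compound 3 `N#Cc1ccc(S(=O)(=O)Nc2cccc3c(Cl)c[nH]c23)cc1` gives 0.13 ug/mL. The two differ by cyano in place of nitro on an aromatic carbon, and that change produced a 2.6-fold lower number from compound 1 to compound 3 (0.42 log units; beyond the scatter). Compound 2 `O=[N+]([O-])c1ccc(S(=O)(=O)Nc2ccc(Cl)c3cc[nH]c23)cc1` has the same atoms as compound 1 joined differently; the difference between the two cores is not broken down here. In this assay compound 2 gives 0.67 ug/mL, a value within the usual scatter of that of compound 1. Compound 4 `N#Cc1ccc(S(=O)(=O)Nc2ccc(Cl)c3cc[nH]c23)cc1` has not yet been measured. It differs from compound 2 by cyano in place of nitro on an aromatic carbon, the same change, at the same place, that separates compound 3 from compound 1. Because of a 2.6-fold lower number from compound 1 to compound 3 (0.42 log units; beyond the scatter), a step of about a 2.6-fold lower number from compound 2 to compound 4 (0.41 log units; beyond the scatter) is expected in this assay. Compound 4 is therefore estimated at 0.26 ug/mL, most likely between 0.12 ug/mL and 0.55 ug/mL.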

Compound 4, half-maximal inhibitory concentration: 0.22 ug/mL
Beside the measured number, compound 4's estimate is 1.2-fold (0.07 log units) above it, and the stated range covers the measured number.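

In this assay, cyano in place of nitro on an aromatic carbon gave a 3.0-fold lower number from compound 2 to compound 4 (0.48 log units; beyond the scatter), so the change kept its direction on the second core. Set beside the earlier step, the new one agrees with it: the same change on two cores in this assay, a 2.6-fold lower number (0.42 log units; beyond the scatter) from compound 1 to compound 3 and a 3.0-fold lower number (0.48 log units; beyond the scatter) from compound 2 to compound 4, 1.2-fold (0.07 log units) apart, within the scatter of two such steps. This shows that the change carried over between these two cores in this one assay; it does not show that it would carry over to any other core, and two pairs cannot explain why the number falls.

The compounds shown hold only nitro or cyano on that aromatic carbon, so it remains open how an amine or a carboxylic acid there would read. On these data alone, whether the same step would appear on other cells also remains open.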